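Amide substituent change in a dihydrofuran series

The source may report more compounds than this note shows. Statements on the series, on what has been measured and on what is new or still open speak of the compounds shown alone.

Measured in a functional assay on HeLa cells (Homo sapiens) for cytotoxicity, read by MTT assay, with a stated time of 24 h; on this read-out lower numbers stand for stronger inhibition and higher numbers for weaker inhibition:
compound 1 `C=CC1=C(C(=O)NCc2ccccc2)C(c2ccc(OC)c(OC)c2)OC1` gives > 100000 nM, a limit of this assay.
compound 2 `C=CC1=C(C(=O)NCCC)C(c2ccc(OC)c(OC)c2)OC1` gives > 100000 nM, a limit of this assay.

Compound 2 stands only at a limit in this assay, and the limit of > 100000 nM in this assay, at which 2 of the 2 values shown sit, is all the evidence here. The step that the two limits leave unreadable from compound 1 to compound 2 is unreadable from the two limits. Compound 3 `C=CC1=C(C(=O)NCc2ccc(C)cc2)C(c2ccc(OC)c(OC)c2)OC1` differs from compound 2 by 4-methylphenyl in place of ethyl on a saturated chain carbon bound to an amide-type nitrogen. Among the measured compounds shown here, no measured step bears readably on this change, so no step beyond the scatter is expected; the estimated step that the limit leaves unreadable from compound 2 to compound 3 follows. Compound 3 is therefore expected to sit at about 200000 nM, between 100000 nM and 1000000 nM, most likely reported again as a limit.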

Compound 3, half-maximal inhibitory concentration: > 100000 nM
Compound 3: no number, only a limit; the forecaster's own chance of this, stated with the estimate: 85%; the middle value lies beyond the limit too.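

Compound 3 adds no readable step to compound 1 or compound 2, because its result is again only a limit: the limit of > 100000 nM in this assay, at which 3 of the 3 values shown sit.
The compounds shown leave open whether any amide substituent on the shared core gives a measurable cytotoxicity value.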